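Trading 4-vinylphenyl for 3-methylphenyl on the shared core

A few compounds are considered here, and "the series" means these few. Any claim that something is new, unique, unknown or untested is made for them only; others in the source may bear on it.

Of the compounds shown here, three sharing one core have been measured so far, and they differ only in the substituted phenyl group on that core. In a functional assay on MCF7 cells (Homo sapiens) for inhibition, read by CCK-8 assay, with a stated time of 48 h (on this read-out lower numbers stand for stronger inhibition and higher numbers for weaker inhibition), compound 1 `COc1cc(-c2ccnc3cc(-c4ccc(Cl)cc4)nn23)cc(OC)c1OC` gives 2320 nM, compound 2 `COc1cc(-c2ccnc3cc(-c4ccc(C)c(C)c4)nn23)cc(OC)c1OC` gives 26 nM, and compound 3 `C=Cc1ccc(-c2cc3nccc(-c4cc(OC)c(OC)c(OC)c4)n3n2)cc1` gives 193 nM. Compound 3 therefore sits in the middle of the three.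

The next compound, compound 4 `COc1cc(-c2ccnc3cc(-c4cccc(C)c4)nn23)cc(OC)c1OC`, has 3-methylphenyl in place of 4-vinylphenyl on an aromatic carbon of a five-membered aromatic ring with 2 nitrogen: 3-methylphenyl in place of 4-vinylphenyl on an aromatic carbon.

The most relevant measurement is a 7.4-fold higher number from compound 2 to compound 3 (0.87 log units; beyond the scatter), a change that also links 4-vinylphenyl to a methyl-bearing phenyl group, 3,4-dimethylphenyl. Two larger steps, an 89-fold lower number from compound 1 to compound 2 (1.95 log units; beyond the scatter) and a 12-fold lower number from compound 1 to compound 3 (1.08 log units; beyond the scatter), show how far the number can move when this group changes, so a wide range is sensible. Within the data shown here, no measured compound carries 3-methylphenyl itself, which leaves its effect open. A modest move towards the number of compound 2 seems the most reasonable expectation, though it may not clear the usual scatter in this assay. The expected change is a 1.8-fold lower number from compound 3 to compound 4 (0.24 log units; within the scatter). The estimated value for compound 4 is 110 nM, within an expected range of 30 nM to 450 nM.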

Compound 4, half-maximal inhibitory concentration: 1080 nM
Estimate against measurement, compound 4: 9.8-fold (0.99 log units) below; the whole stated range lies below it.
By their numbers in this assay, from the lowest: compound 2; then compound 3; then compound 4; then compound 1.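

In this assay the removal of one methyl from 3,4-dimethylphenyl, leaving 3-methylphenyl, gives a 42-fold higher number from compound 2 to compound 4 (1.62 log units; beyond the scatter) and so shows that a change as small as hydrogen in place of methyl can move the number a long way at this position. Among these compounds, the swap of 4-vinylphenyl for 3-methylphenyl gives a 5.6-fold higher number from compound 3 to compound 4 (0.75 log units; beyond the scatter) and, with a 2.1-fold lower number from compound 1 to compound 4 (0.33 log units; beyond the scatter) as the only step that separates 3-methylphenyl from 4-chlorophenyl, places this single methyl group much closer to the high end of the series than to compound 2, so a methyl on the phenyl ring does not by itself bring a low number. Nothing shown here accounts for these differences.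

A compound with 4-methylphenyl on the shared core would show whether the methyl that remains in compound 4 contributes anything to the low number of compound 2, or whether the other methyl accounts for most of it. Also open, from the compounds shown here alone, is how this position responds to a longer chain such as ethyl or propyl, or to an amine or a methoxy group on the phenyl ring.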